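The compounds below may be only part of what the source reports. "The series", "measured", "known", "first", "only" and "open" are said of these compounds alone.

Compound 1 `C/C=C(C)/C=C/[C@](C)(O)C/C=C/[C@H]1[C@H](O)CC(=O)[C@@H]1CC/C=C\CCC(=O)OC`: 0.000003 mg/kg
Compound 2 `C=C/C=C/[C@](C)(O)C/C=C/[C@H]1[C@H](O)CC(=O)[C@@H]1CC/C=C\CCC(=O)OC`: 0.000007 mg/kg
Compound 3 `C/C=C/C=C/[C@](C)(O)C/C=C/[C@H]1[C@H](O)CC(=O)[C@@H]1CC/C=C\CCC(=O)OC`: 0.00003 mg/kg

In a functional assay on the whole organism with Canis familiaris (Canis lupus familiaris) as the target (on this read-out lower numbers stand for an effect already at smaller amounts and higher numbers for an effect only at larger amounts of compound), compound 2 stands second highest of the three numbers, with compound 1 nearest and compound 3 furthest. Compound 4 `CCCCC(C)(O)C/C=C/[C@H]1[C@H](O)CC(=O)[C@@H]1CC/C=C\CCC(=O)OC` differs from compound 2 by 1-hydroxy-1-methylpentyl in place of 1-hydroxy-1-methylpenta-2,4-dien-1-yl on a saturated chain carbon bound to a double-bonded chain carbon. Every change made so far in this part of the chain raised the number: a 2.3-fold higher number from compound 1 to compound 2 (0.37 log units; beyond the scatter), a 4.3-fold higher number from compound 2 to compound 3 (0.63 log units; beyond the scatter) and a 10-fold higher number from compound 1 to compound 3 (1.00 log units; beyond the scatter). Removing both double bonds of that chain is a larger change than any of these, so a clearly higher number is expected, likely beyond the largest step seen. For compound 4 the expected step is a 29-fold higher number from compound 2 to compound 4 (1.46 log units; beyond the scatter). Compound 4 is therefore estimated at 0.0002 mg/kg, within 0.00003 mg/kg to 0.002 mg/kg.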

Compound 4, dose for half-maximal effect: 0.000023 mg/kg
The estimate for compound 4 lay 8.7-fold (0.94 log units) above the measured number; the whole stated range lies above it.
By their numbers in this assay, from the lowest: compound 1; then compound 2; then compounds 4 and 3 (each within the scatter of the next).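

In this assay the double bonds of this chain are not needed for an effect at very small doses: the saturated 1-hydroxy-1-methylpentyl group still gives a 3.3-fold higher number from compound 2 to compound 4 (0.52 log units; beyond the scatter) and a 7.7-fold higher number from compound 1 to compound 4 (0.88 log units; beyond the scatter) in a modest range. The saturated chain also cannot be told apart from the chain of compound 3, with a 1.3-fold lower number from compound 3 to compound 4 (0.12 log units; within the scatter) as the step. Nothing measured here explains these steps.

Still open, from the compounds shown here alone, is how an amine or a carboxylic acid at the end of this chain would read, and whether a longer saturated chain would keep the effect.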